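The source may report more compounds than this note shows. Statements on the series, on what has been measured and on what is new or still open speak of the compounds shown alone.

Measured so far in a functional assay on MDA-MB-231 cells (Homo sapiens) for cytotoxicity, read by MTT assay, with a stated time of 48 h; a lower number here means a stronger inhibitor, a higher number a weaker inhibitor:

- compound 1 `O=C(NCCCCC(c1ccc(F)cc1)c1ccc(F)cc1)Nc1cccc(Cl)c1`: 5070 nM
- compound 2 `O=C(NCCCCC(c1ccc(OC(F)(F)F)cc1)c1ccc(OC(F)(F)F)cc1)Nc1ccc(Cl)c(C(F)(F)F)c1`: 1690 nM
- compound 3 `O=C(NCCCCN(c1ccc(F)cc1)c1ccc(F)cc1)Nc1ccc(Cl)cc1`: > 20000 nM

Compound 1 gives the highest of the two numbers in this assay. Compound 2 sits clearly lower, beyond the scatter of repeated measurements. Compound 3 returns only a limit in this assay, (the limit of > 20000 nM in this assay, at which 1 of the 3 values shown sits), and no number is known for it.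

The step from compound 1 to compound 4 `O=C(NCCCCC(c1ccc(F)cc1)c1ccc(F)cc1)c1ccc(Cl)c(C(F)(F)F)c1` changes one place on the shared core: 4-chloro-3-(trifluoromethyl)phenyl in place of (3-chlorophenyl)amino on a carbonyl carbon. The group that enters is the same one carried by compound 2, which gives the lower number of the two measured in this assay. Within the data shown here, no measured step isolates this change, so the expectation rests on that comparison alone.

A step downward in this assay is expected, modest rather than large, with a 1.7-fold lower number from compound 1 to compound 4 (0.23 log units; within the scatter) as the estimated size. For compound 4 the expected value in this assay is 3000 nM, in a range from 1000 nM to 10000 nM.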

Compound 4, half-maximal inhibitory concentration: 11700 nM
Compound 4: middle estimate off by 3.9-fold (0.59 log units), on the low side, and the stated range ends below it.
By their numbers in this assay, from the lowest: compound 2; then compound 1; then compound 4. At a limit, above all of these: compound 3.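

In this assay, among these compounds, the exchange on a carbonyl carbon, where (3-chlorophenyl)amino leaves and 4-chloro-3-(trifluoromethyl)phenyl enters, gives a 2.3-fold higher number from compound 1 to compound 4 (0.36 log units; beyond the scatter), the first readable one-place step, and it points towards a weaker inhibitor. The change removes a hydrogen-bond donor and alters the aromatic substituents at once, and this single step cannot separate those changes; compound 2 carries the same group but differs from compound 4 in more than one place, so it does not settle the matter. No measurement shown here offers a cause for this step.

Open, going by these compounds, is how 3-chlorophenyl or (4-chloro-3-(trifluoromethyl)phenyl)amino on that carbonyl carbon would read, as either would help to divide the step between the amide hydrogen and the ring substituents. Also open, on these data alone, is whether a longer chain in the shared core would shift the reading.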